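A few compounds are considered here, and "the series" means these few. Any claim that something is new, unique, unknown or untested is made for them only; others in the source may bear on it.

Within the data shown here, compound 1, `Cc1nc(SCC(=O)Nc2nc(-c3ccc(Cl)cc3)cs2)n(Nc2ccccc2)c1C`, is the weaker of the two compounds measured so far in a functional assay on OVCAR-4 cells (Homo sapiens) for antiproliferative activity, read by sulforhodamine B assay, with a stated time of 48 h; on this read-out higher numbers stand for weaker inhibition of growth and lower numbers for stronger inhibition of growth: in this assay compound 1 gives 4600 nM. Among the measured compounds shown here, the only other compound with a number, compound 2, `Cc1ccc(Nn2c(SCC(=O)Nc3nc(-c4ccccc4)cs3)nc(C)c2C)cc1`, differs from compound 1 in more than one place, and in this assay compound 2 gives 2130 nM; the two values show a gap that lies beyond the usual scatter, but no single structural step connects them.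

The next compound, compound 3, `COc1ccc(Nn2c(SCC(=O)Nc3nc(-c4ccc(Cl)cc4)cs3)nc(C)c2C)cc1`, is made from compound 1 by one change: methoxy in place of hydrogen on an aromatic carbon. For the measured compounds named here, there is no measured pair that carries this change alone, so the size of its effect is not known from the data. The shared core, the thioacetamide linker and the chlorophenyl-bearing thiazole are all kept, and only the substituent on the anilino ring is new.

On this basis compound 3 is expected to land close to compound 1, with at most a modest move toward stronger inhibition, an estimated step of a 1.4-fold lower number from compound 1 to compound 3 (0.16 log units; within the scatter). The value expected for compound 3 in this assay is 3200 nM, within a range of 1000 nM to 10000 nM.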

Compound 3, concentration for 50% growth inhibition: 4020 nM
Compound 3: middle estimate off by 1.3-fold (0.10 log units), on the low side, and the stated range covers the measured number.
By their numbers in this assay, from the lowest: compounds 2, 3 and 1 (each within the scatter of the next, the first and the last beyond it).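

Among these compounds, the first single-change step falls on the anilino ring: in this assay, going from phenyl to 4-methoxyphenyl gives a 1.1-fold lower number from compound 1 to compound 3 (0.06 log units; within the scatter), which lies within the usual scatter. At this aromatic carbon, para to a large group, methoxy in place of hydrogen therefore leaves compound 1 and compound 3 indistinguishable on this read-out, so this one substitution shows no measurable effect on growth inhibition in these cells. No measurement is available that would explain this outcome.

From the compounds shown here alone, it remains open whether a dimethylamino group, a carboxylic acid or a longer chain such as butoxy on the same aromatic carbon would give a step beyond the scatter, since a single methoxy group cannot show how this position responds to other substituents. Also open, going by these compounds, is whether methoxy would give an equally small step elsewhere on the anilino ring, or at this same place in a compound without the chlorine on the chlorophenyl group.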